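The source may hold more compounds than are shown below. What is called first, only, known or untested is meant among the compounds shown, and "the series" means these compounds.

In a set built on one shared core, compound 1 `COc1ccc(/C=C2/CN(C)/C(=N/c3ccc(C)cc3)S2)cc1` gives 65700 nM in an ADME assay on TERT-RPE1 cells (Homo sapiens) for cytotoxicity, read by MTT assay, with a stated time of 72 h (on this read-out lower numbers stand for stronger inhibition and higher numbers for weaker inhibition), compound 2 `COc1ccc(/C=C2\S/C(=N\c3ccc(C(C)(C)C)cc3)N(C)C2=O)cc1` gives 46700 nM in this assay, and compound 3 `COc1ccc(/C=C2/CN(C)/C(=N/c3ccc(Cl)cc3)S2)cc1` gives 39600 nM in this assay. The three numbers all lie within the scatter of one another, so compound 3 is not set apart from compound 1 or compound 2. Within the data shown here, the only single-point step measured so far is a 1.7-fold lower number from compound 1 to compound 3 (0.22 log units; within the scatter), a change at the same aromatic position that the next compound alters. Compound 4 `COc1ccc(/C=C2/CN(C)/C(=N/c3ccc(F)cc3)S2)cc1` differs from compound 3 by fluoro in place of chloro on an aromatic carbon. Among the measured compounds shown here, since the one comparable swap gave a 1.7-fold lower number from compound 1 to compound 3 (0.22 log units; within the scatter), the account expects no step beyond the scatter, a 1.1-fold higher number from compound 3 to compound 4 (0.03 log units; within the scatter). For compound 4 the estimate is therefore 42000 nM, within 20000 nM to 85000 nM.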

Compound 4, half-maximal inhibitory concentration: 42800 nM
For compound 4 the middle estimate is 1.0-fold (0.01 log units) below the measured one, and the stated range covers the measured number.
By their numbers in this assay, from the lowest: compounds 3, 4, 2 and 1 (each within the scatter of the next).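

With methyl, chloro and fluoro now all read at this place on the shared core in this assay, fluoro in place of chloro gives a 1.1-fold higher number from compound 3 to compound 4 (0.03 log units; within the scatter) and fluoro in place of methyl gives a 1.5-fold lower number from compound 1 to compound 4 (0.19 log units; within the scatter). On an aromatic carbon para to a large group, these three substituents are thus not told apart by this read-out. No supporting evidence bears on this result. From the compounds shown here alone, whether an amine, a carboxylic acid or a longer chain at this place would give a step beyond the scatter stays open. Also open, going by these compounds, is whether a change elsewhere on the shared core would do so.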